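Notes on side-chain variation in a nucleoside series

A few compounds are considered here, and "the series" means these few. Any claim that something is new, unique, unknown or untested is made for them only; others in the source may bear on it.

Measured so far:
compound 1, `Nc1nc(O)c2c(n1)n(C1OC(CO)[C@@H](O)[C@H]1O)c(=O)n2C/C=C/c1ccccc1`, gives 73% in a functional assay on the whole organism (B cells) with Mus musculus as the target; a lower number here means a smaller maximal response, a higher number a larger maximal response
compound 2, `CN(C)CCCn1c(=O)n(C2OC(CO)[C@@H](O)[C@H]2O)c2nc(N)nc(O)c21`, gives 83%

In this assay, among the compounds with values here, compound 2 holds the higher of the two numbers, but its only neighbour, compound 1, sits within the scatter of it: a number 10 percentage points higher from compound 1 to compound 2 (within the scatter). So the two measured compounds cannot be ordered on maximal response.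

Compound 3, `CCCCCCCCCCn1c(=O)n(C2OC(CO)[C@@H](O)[C@H]2O)c2nc(N)nc(O)c21`, differs from compound 2 by heptyl in place of dimethylamino on a saturated chain carbon, three bonds along the chain from an aromatic nitrogen. Within the data shown here, no measured step bears directly on this change. Among the measured compounds shown here, the single step available, a number 10 percentage points higher from compound 1 to compound 2 (within the scatter), exchanges 2-phenylethenyl for 2-(dimethylamino)ethyl at the same position and did not move the maximal response beyond the scatter; it says nothing about replacing dimethylamino with heptyl. With one step only, and that within the scatter, there is no ground to expect a step beyond the scatter in this assay from compound 2 to compound 3.

Compound 3 is therefore expected to give about 78%, within 60% to 95%. The step that this estimate means, a number 5 percentage points lower from compound 2 to compound 3 (within the scatter), is expected to remain within the scatter.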

Compound 3, largest response reached (reported as maximal response), in percent of the reference or control that the assay uses: 0%
Beside the measured number, compound 3's estimate is 78 percentage points above it, and the stated range ends above it.
By their numbers in this assay, from the lowest: compound 3; then compounds 1 and 2 (each within the scatter of the next).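

In this assay this position proves far from indifferent: heptyl in place of dimethylamino, on a saturated chain carbon three bonds along the chain from an aromatic nitrogen, gives a number 83 percentage points lower from compound 2 to compound 3 (beyond the scatter) and removes the response that the earlier side chains left in place. Nonyl in place of 2-phenylethenyl, on a saturated chain carbon bound to an aromatic nitrogen, gives a number 73 percentage points lower from compound 1 to compound 3 (beyond the scatter) as well, so the decyl chain of compound 3 stands apart from both earlier side chains, which themselves cannot be ordered. Compound 1 also carries no dimethylamino group and still sits within the scatter of compound 2, so the loss in compound 3 does not follow from removing that amine alone, and nothing at hand bears on what lies behind it.

The compounds shown give only one long saturated chain, so they leave open whether the response falls gradually or abruptly as the chain grows, which a hexyl or a dodecyl chain at this position would help to settle. They also leave open whether a decyl chain ending in a dimethylamino group or a carboxylic acid would restore the response.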